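This account rests on a few compounds, and the source may have more. Where it says the series, first, only, none or still open, it means among the compounds named here.

Compound 3 `CCCCCCCCCCCCCCCCCCSC[C@H](NC(C)=O)C(=O)CCl` carries the longest chain of the three measured compounds, and in a functional assay on NALM-6 cells (Homo sapiens) (on this read-out lower numbers stand for stronger inhibition and higher numbers for weaker inhibition), compound 3 reaches only the limit of > 100000 nM. Compound 1 `CCCCCCCCCCCCCCSC[C@H](NC(C)=O)C(=O)CCl` gives 8700 nM in this assay, and compound 2 `CCCCCCCCCCCCCCCSC[C@H](NC(C)=O)C(=O)CCl` gives 8900 nM. Compound 4 `CCCCCCCCCCCCCCCCCCCCSC[C@H](NC(C)=O)C(=O)CCl` differs from compound 3 by ethyl in place of hydrogen on a saturated chain carbon, ten or more bonds along the chain from a sulfur. Among the measured compounds shown here, the steps that bear on this change are an at least 11-fold higher number from compound 1 to compound 3 (1.06 log units; beyond the scatter) and an at least 11-fold higher number from compound 2 to compound 3 (1.05 log units; beyond the scatter), whereas a 1.0-fold higher number from compound 1 to compound 2 (0.01 log units; within the scatter). Since compound 3 already sits at the limit (the limit of > 100000 nM in this assay, at which 1 of the 3 values shown sits), further lengthening of the chain is expected to leave compound 4 at or beyond that limit, so the step that the limit leaves unreadable from compound 3 to compound 4 is estimated as no further change that could be resolved. Compound 4 is therefore expected to give about 150000 nM, between 50000 nM and 600000 nM.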

Compound 4, half-maximal inhibitory concentration: > 100000 nM
Compound 4 was reported as a limit; the forecaster's own chance of this, stated with the estimate: 90%; the middle value does not contradict the limit.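

In this assay compound 4 gives > 100000 nM as a limit of the assay and not as a number. Against the shorter chains the result reads as an at least 11-fold higher number from compound 2 to compound 4 (1.05 log units; beyond the scatter) and as an at least 11-fold higher number from compound 1 to compound 4 (1.06 log units; beyond the scatter) so the weak read-out of compound 3 extends to a second, longer chain. The step from compound 3 to compound 4 cannot be read, and both compounds stand at one limit: the limit of > 100000 nM in this assay, at which 2 of the 4 values shown sit.

The compounds shown leave open where in the gap from the chain of compound 2 to that of compound 3 the read-out is lost. They also leave open how a chain shorter than that of compound 1, or a chain carrying an amine, would read in this assay.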